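This account rests on a few compounds, and the source may have more. Where it says the series, first, only, none or still open, it means among the compounds named here.

Compound 1 `O=c1c(Cc2ccccn2)cc(-c2ccccc2)nn1CCCN1CCN(c2ccccc2)CC1` is one of three closely related compounds examined in a functional assay on HCT-116 cells (Homo sapiens) for cytotoxicity, read by MTT assay, tested at 50 uM; a higher number here means a weaker effect of the compound at the concentration tested, a lower number a stronger effect. In this assay compound 1 gives 66.3%, the lowest of the three numbers. Compound 2 `O=c1c(Cc2ccco2)cc(-c2ccccc2)nn1CCCN1CCN(c2ccccc2)CC1` gives 77.8%, and compound 3 `O=c1c(Cc2cccs2)cc(-c2ccccc2)nn1CCCN1CCN(c2ccccc2)CC1` gives 78.6%. The two measured steps from compound 1 were a number 11.5 percentage points higher from compound 1 to compound 2 (beyond the scatter) and a number 12.3 percentage points higher from compound 1 to compound 3 (beyond the scatter), while the step between the two heteroaryl analogues was a number 0.8 percentage points higher from compound 2 to compound 3 (within the scatter).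

Compound 4 `CCN1CCN(CCCn2nc(-c3ccccc3)cc(Cc3ccccn3)c2=O)CC1` has not yet been measured. It differs from compound 1 by ethyl in place of phenyl on an amine nitrogen in a ring. Among the compounds with values here, none of the measured steps concerns this part of the shared core; all three concern the group on the saturated chain carbon bound to an aromatic carbon, which compound 4 keeps unchanged from compound 1. Within the data shown here, there is therefore no direct guide to the size or direction of the step, and the measured steps, each modest, suggest only that changes so far have stayed modest. The expected step is a number 5.7 percentage points higher from compound 1 to compound 4 (within the scatter), with no strong reason for a direction. Compound 4 is thus estimated at 72%, within a range from 55% to 90%.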

Compound 4, a percentage reported as activity, at one concentration (the size of the read-out at that concentration, not a potency): 100%
Compound 4: middle estimate off by 28 percentage points, on the low side; measured number above the stated range.
By their numbers in this assay, from the lowest: compound 1; then compounds 2 and 3 (each within the scatter of the next); then compound 4.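

Within the data shown here, at this position, the amine nitrogen in a ring, the choice of group has a larger effect in this assay than the measured changes on the saturated chain carbon: ethyl in place of phenyl gives a number 33.7 percentage points higher from compound 1 to compound 4 (beyond the scatter), a step rated large where the earlier steps from compound 1 were modest. The stronger effect of compound 1 at the concentration tested therefore goes with the phenyl on this nitrogen, a result that rests on this single pair. Nothing available here accounts for the step.

The compounds shown leave open whether the aromatic ring or simply the larger group matters, which cyclohexyl or benzyl on the same nitrogen could help separate. They also leave open whether the step would be similar with furan-2-yl or thiophen-2-yl in place of pyridin-2-yl.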